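The compounds below may be only part of what the source reports. "The series", "measured", "known", "first", "only" and "open" are said of these compounds alone.

Compound 2 `CCN(CC)c1cc2[nH]c(C3CCCCC3)nc2cc1NC(=O)c1ccc(N(C)C)cc1` is the point of departure. In an ADME assay on Vero cells (Chlorocebus sabaeus) for cytotoxicity, read by resazurin assay, with a stated time of 3 days (a lower number here means a stronger inhibitor, a higher number a weaker inhibitor), compound 2 gives "not determined" (no result reported), so no number places it. Compound 1 `CN(C)c1cc2[nH]c(C3CCCCC3)nc2cc1NC(=O)c1ccc(Br)cc1` gives only a limit of the assay, > 100 ug/mL. Compound 3 `CN(C)c1cc2[nH]c(C3CCCCC3)nc2cc1NC(=O)c1ccc(C(C)(C)C)cc1` likewise gives only a limit, > 100 ug/mL. For the measured compounds named here, the single step among measured compounds, a step that the two limits leave unreadable from compound 1 to compound 3, is therefore of unreadable size, and the one piece of evidence is the limit of > 100 ug/mL in this assay, at which 2 of the 3 values shown sit. Compound 4 `CCN(CC)c1cc2[nH]c(C3CCCCC3)nc2cc1NC(=O)OCCOCCOC` differs from compound 2 by 2-(2-methoxyethoxy)ethoxy in place of 4-(dimethylamino)phenyl on a carbonyl carbon. Going by the values given here, no measured step covers this change, and the two limits show only that neither neighbour reached a number. Compound 4 is accordingly expected to sit near that limit too, estimated at 100 ug/mL, from 50 ug/mL to 200 ug/mL.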

Compound 4, half-maximal inhibitory concentration: > 100 ug/mL
Compound 4 was reported as a limit (the forecaster's own chance of this, stated with the estimate: 80%); the middle value lies on the limit itself.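

In this assay compound 4 gives only a limit, > 100 ug/mL, so no step can be read from compound 2 to compound 4. From the compounds shown here alone, whether 2-(2-methoxyethoxy)ethoxy in place of 4-(dimethylamino)phenyl shifts the read-out at all stays open.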